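Swapping a chloropyridyl for a chlorophenyl on the thiazole

The source may report more compounds than this note shows. Statements on the series, on what has been measured and on what is new or still open speak of the compounds shown alone.

Compound 1 `COc1ccc(-c2c(C#N)c(N)nc(SCc3nc(-c4ccc(Cl)cc4)sc3Br)c2C#N)cc1`: 162 nM
Compound 2 `COc1ccc(-c2c(C#N)c(N)nc(SCc3nc(-c4ccc(Cl)cc4)sc3Cl)c2C#N)cc1`: 88 nM
Compound 3 `COc1ccc(-c2c(C#N)c(N)nc(SCc3csc(-c4ccc(Cl)cn4)n3)c2C#N)cc1`: 24 nM

In an assay on CHO cells for displacement of a labelled ligand from adenosine receptor A1 (Homo sapiens) (a lower number here means a stronger inhibitor, a higher number a weaker inhibitor), compound 3 gives the lowest number of the three, with compound 2 at 88 nM and compound 1 at 162 nM both clearly weaker. Compound 4 `COc1ccc(-c2c(C#N)c(N)nc(SCc3csc(-c4ccc(Cl)cc4)n3)c2C#N)cc1` is compound 3 with a change of the aryl group: 4-chlorophenyl in place of 5-chloropyridin-2-yl on an aromatic carbon. For the measured compounds named here, no measured step covers this swap. Going by the values given here, the only step measured, a 1.8-fold lower number from compound 1 to compound 2 (0.27 log units; within the scatter), concerns a different position and stays within the scatter, so it says little here. Compounds 1 and 2, which carry the 4-chlorophenyl, are weaker than compound 3, but they also bear an extra halogen, so a modest weakening is expected, a 2.1-fold higher number from compound 3 to compound 4 (0.32 log units; beyond the scatter). Compound 4 is estimated at 50 nM, between 15 nM and 160 nM.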

Compound 4, inhibition constant: 5 nM
Compound 4: middle estimate off by 10-fold (1.00 log units), on the high side, and the stated range ends above it.
By their numbers in this assay, from the lowest: compound 4; then compound 3; then compounds 2 and 1 (each within the scatter of the next).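

In this assay, 4-chlorophenyl in place of 5-chloropyridin-2-yl gives a 4.8-fold lower number from compound 3 to compound 4 (0.68 log units; beyond the scatter), so at this position the ring of carbon only beats the ring holding a nitrogen. Keeping the 4-chlorophenyl, hydrogen in place of chloro gives an 18-fold lower number from compound 2 to compound 4 (1.25 log units; beyond the scatter) and hydrogen in place of bromo gives a 32-fold lower number from compound 1 to compound 4 (1.51 log units; beyond the scatter), so both halogens on the five-membered ring come with much weaker binding than hydrogen. Nothing available explains why either change lowers the number. Still open, going by these compounds, is whether a methyl or an amine on that ring carbon would match hydrogen, and whether fluoro could replace the chloro on the phenyl.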